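Chloro for cyano on the aryloxyacetic acid series

The source may hold more compounds than are shown below. What is called first, only, known or untested is meant among the compounds shown, and "the series" means these compounds.

Measured so far:
compound 1 `COc1ccccc1C#Cc1cc(Cl)ccc1OCC(=O)O` 190 nM
compound 2 `O=C(O)COc1ccc(Cl)cc1C#Cc1ccncc1` 601 nM
compound 3 `N#Cc1ccc(OCC(=O)O)c(C#Cc2ccccc2Cl)c1` 24 nM

All three values come from an assay on CHO cells for displacement of a labelled ligand from prostaglandin D2 receptor 2 (Homo sapiens), read by scintillation counting; a higher number here means a weaker inhibitor, a lower number a stronger inhibitor. Compound 3 stands lowest of the three numbers; compound 1 sits at a higher number and compound 2 higher still, both gaps beyond the scatter, so compound 3 counts as the strongest inhibitor of the set so far. Among the compounds with values here, no pair of the measured compounds differs in one place only, so no isolated step is available.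

Compound 4 `O=C(O)COc1ccc(Cl)cc1C#Cc1ccccc1Cl` is not yet measured in this assay. It differs from compound 3 by chloro in place of cyano on an aromatic carbon. Compound 1 and compound 2 also carry chloro rather than cyano, and both give higher numbers than compound 3, but each also bears a different second aryl group, so the effect of the chloro-for-cyano exchange alone cannot be read from them.

The expectation for compound 4 in this assay is a moderate rise in the number, estimated as a 2.5-fold higher number from compound 3 to compound 4 (0.40 log units; beyond the scatter), a loss beyond the scatter but smaller than the gaps to compound 1 and compound 2. Compound 4 is therefore estimated at 60 nM, within a range of 18 nM to 200 nM.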

Compound 4, inhibition constant: 28 nM
Compound 4: the middle estimate sits 2.1-fold (0.33 log units) above what was measured; the measured number falls inside the stated range.
By their numbers in this assay, from the lowest: compounds 3 and 4 (each within the scatter of the next); then compound 1; then compound 2.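

Notes on the chloro and cyano position: in this assay, with the 2-chlorophenyl group held constant, the exchange of cyano for chloro para to the carboxymethoxy group leaves the number within the scatter (a 1.2-fold higher number from compound 3 to compound 4 (0.07 log units; within the scatter)), so this position tolerates either group in this pair. Compound 4 also separates the effects that compounds 1 and 2 left mixed, with the larger change tied to 2-chlorophenyl in place of pyridin-4-yl on a triple-bonded carbon (a 21-fold lower number from compound 2 to compound 4 (1.33 log units; beyond the scatter)) and a smaller one to the exchange of methoxy for chloro (a 6.8-fold lower number from compound 1 to compound 4 (0.83 log units; beyond the scatter)), both beyond the scatter, so in these steps the number moves with the aryl group on the triple bond rather than with the chloro-for-cyano exchange. No measurement at hand explains any of these three steps.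

On these data alone, whether chloro and cyano stay interchangeable when pyridin-4-yl or the methoxy-bearing aryl group sits on the triple bond remains open. Also open, as far as these compounds go, is how a methyl, trifluoromethyl or carboxamide group at the same position would compare with chloro and cyano.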